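The source may hold more compounds than are shown below. What is called first, only, known or untested is meant among the compounds shown, and "the series" means these compounds.

The compounds measured so far:

Compound 1 `CCCCN(C)c1nc(C(C)(C)C)ccc1CNC(=O)C(C)c1ccc(NS(C)(=O)=O)c(F)c1`: 1.2 nM in an assay on cells for antagonist activity at transient receptor potential cation channel subfamily V member 1 (Homo sapiens), read by FLIPR and calcium flux, with a stated time of 6 min; a lower number here means a stronger inhibitor, a higher number a weaker inhibitor
Compound 2 `CC(C(=O)NCc1ccc(C(C)(C)C)nc1N1CCCCCC1)c1ccc(NS(C)(=O)=O)c(F)c1`: 0.9 nM in this assay
Compound 3 `CC(C(=O)NCc1ccc(C(C)(C)C)nc1SCc1ccccc1)c1ccc(NS(C)(=O)=O)c(F)c1`: 4 nM in this assay

Compound 2 gives the lowest number of the three. Its value and that of compound 1 lie within the scatter of each other (a 1.3-fold lower number from compound 1 to compound 2 (0.12 log units; within the scatter)), while compound 3 stands apart from it (a 4.4-fold higher number from compound 2 to compound 3 (0.65 log units; beyond the scatter)).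

Compound 4 `COc1ccc(CSc2nc(C(C)(C)C)ccc2CNC(=O)C(C)c2ccc(NS(C)(=O)=O)c(F)c2)cc1` has not yet been measured in this assay. It differs from compound 2 in one place:
(4-methoxybenzyl)sulfanyl in place of azepan-1-yl on an aromatic carbon

Within the data shown here, two measured steps bear on this change. Replacing an amine substituent with benzylsulfanyl raised the number in both cases: a 3.3-fold higher number from compound 1 to compound 3 (0.52 log units; beyond the scatter) and a 4.4-fold higher number from compound 2 to compound 3 (0.65 log units; beyond the scatter). Compound 4 carries a (4-methoxybenzyl)sulfanyl group, the benzylsulfanyl of compound 3 with an added methoxy. Among the measured compounds shown here, no measured pair shows what the methoxy alone does, so that part of the change is given no weight, and a step of about the same size and direction as the one from compound 2 to compound 3 is expected: a modest rise, beyond the scatter. The expected step is a 4.4-fold higher number from compound 2 to compound 4 (0.65 log units; beyond the scatter). Compound 4 is therefore estimated at 4 nM, with a range from 1.5 nM to 11 nM.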

Compound 4, inhibition constant: 3.5 nM
Beside the measured number, compound 4's estimate is 1.1-fold (0.06 log units) above it, and the stated range covers the measured number.
By their numbers in this assay, from the lowest: compounds 2 and 1 (each within the scatter of the next); then compounds 4 and 3 (each within the scatter of the next).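

In this assay, among these compounds, adding a methoxy to the benzylsulfanyl group on the aromatic carbon next to the ring nitrogen gives the first direct reading of that addition, and the change stays within the scatter (a 1.1-fold lower number from compound 3 to compound 4 (0.06 log units; within the scatter)). The rise seen on leaving the amine substituents therefore also appears with (4-methoxybenzyl)sulfanyl, modest and beyond the scatter against both azepan-1-yl (a 3.9-fold higher number from compound 2 to compound 4 (0.59 log units; beyond the scatter)) and butyl(methyl)amino (a 2.9-fold higher number from compound 1 to compound 4 (0.46 log units; beyond the scatter)), and no compound shown goes against this split between the two sulfur-linked groups and the two amine groups. No measurement at hand explains either the gap between these two sets or the lack of a clear methoxy effect.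

Going by these compounds, the sulfur and the benzyl part enter together in every step from an amine, so it stays open which of them goes with the higher numbers, a question that a methylsulfanyl or a benzyloxy group at this place would address. A single methoxy also says little about other substituents on the benzyl ring, such as a chlorine or a hydroxyl group.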